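Cytotoxicity on Vero Cells: Swapping the Basic Ring

The source may hold more compounds than are shown below. What is called first, only, known or untested is meant among the compounds shown, and "the series" means these compounds.

Measured compounds:
Compound 1 `Cn1c(-c2ccc([N+](=O)[O-])cc2)nc2cc(C(F)(F)F)ccc21`: > 100000 nM
Compound 2 `CN1CCN(CC(=O)Nc2ccc(-c3nc4cc(C(F)(F)F)ccc4n3C)cc2)CC1`: > 100000 nM

Both compounds share the same core and were tested in an ADME assay on Vero cells (Chlorocebus sabaeus) for cytotoxicity; on this read-out higher numbers stand for lower toxicity in this test and lower numbers for higher toxicity in this test. In this assay compound 1 gives > 100000 nM, which is a limit of the test and not a number. In this assay compound 2 gives > 100000 nM, again a limit rather than a number. Compound 2 therefore sits at the limit of > 100000 nM in this assay, at which 2 of the 2 values shown sit, so no numerical position can be given for it beyond that limit.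

Compound 3 `Cn1c(-c2ccc(NC(=O)CN3CCCC3)cc2)nc2cc(C(F)(F)F)ccc21` has not yet been measured. It differs from compound 2 in one place: pyrrolidin-1-yl in place of 4-methylpiperazin-1-yl on a saturated chain carbon bound to a carbonyl carbon. Going by the values given here, no pair of measured compounds shows a step of this kind, so there is no measured size to lean on.

Because compound 2 gives only > 100000 nM as a limit, and because compound 1 sits at the same limit with > 100000 nM, the expectation is that the step from compound 2 to compound 3 stays within the scatter, estimated as a number no higher from compound 2 to compound 3 (the limit leaves the size open). Compound 3 is expected to give about 100000 nM in this assay, with a range from 50000 nM to 200000 nM.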

Compound 3, half-maximal cytotoxic concentration: > 100000 nM
Compound 3 was reported as a limit (the forecaster's own chance of this, stated with the estimate: 75%); the middle value sits exactly at the limit.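

In this assay, going by these compounds alone, compound 3 gives > 100000 nM, which is a limit and not a number, so no step from compound 1 or compound 2 to compound 3 can be read. Compound 1, compound 2 and compound 3 all sit at the same place: the limit of > 100000 nM in this assay, at which 3 of the 3 values shown sit.

The compounds shown leave open whether pyrrolidin-1-yl and 4-methylpiperazin-1-yl differ at all in this assay.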